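Swapping Chlorine for Fluorine on the Sulfonamide Ring

A few compounds are considered here, and "the series" means these few. Any claim that something is new, unique, unknown or untested is made for them only; others in the source may bear on it.

Of the compounds shown here, two have so far been measured in a functional assay on aorta for antagonist activity at thromboxane A2 receptor (Rattus norvegicus); a lower number here means tighter binding, a higher number weaker binding. Compound 1 `O=C(O)CCn1cc(Cc2ccc(F)cc2)c2cc(NS(=O)(=O)c3ccc(F)cc3)ccc21` gives 0.479 nM in this assay. Compound 2 `O=C(O)CCn1ccc2cc(NS(=O)(=O)c3ccc(Cl)cc3)ccc21` gives 2.75 nM in this assay, the higher of the two numbers, and its gap to compound 1 lies beyond the usual scatter. These two compounds differ in more than one place, so the pair says nothing about any single change. Compound 3 `O=C(O)CCn1ccc2cc(NS(=O)(=O)c3ccc(F)cc3)ccc21` has not been measured yet. It differs from compound 2 by fluoro in place of chloro on an aromatic carbon. Among the compounds with values here, no measured pair shows this change on its own, so the expectation rests on general experience with such swaps. This change is expected to shift the number only a little, likely not beyond the scatter, as the step of a 1.3-fold higher number from compound 2 to compound 3 (0.10 log units; within the scatter). Compound 3 is therefore estimated at 3.5 nM in this assay, with a range from 1.4 nM to 9 nM.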

Compound 3, dissociation constant: 3.72 nM
Estimate against measurement, compound 3: 1.1-fold (0.03 log units) below; the range from low to high includes it.
By their numbers in this assay, from the lowest: compound 1; then compounds 2 and 3 (each within the scatter of the next).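

Fluoro in place of chloro gives a 1.4-fold higher number from compound 2 to compound 3 (0.13 log units; within the scatter) in this assay, so at this position 4-chlorophenyl and 4-fluorophenyl cannot be told apart in this measurement. A clearer signal comes from the other single change, hydrogen in place of 4-fluorobenzyl, which gives a 7.8-fold higher number from compound 1 to compound 3 (0.89 log units; beyond the scatter) and ties the tighter binding of compound 1 to the presence of that group on the shared core. Nothing measured here explains why either step has the size it does. The compounds shown leave open whether a bromo or methoxy group on the same ring would also stay within the scatter of fluoro and chloro. They also leave open whether plain benzyl or a longer chain ending in a phenyl ring could replace 4-fluorobenzyl and keep the tighter binding.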